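From 2,4-dimethoxyphenyl to 4-hydroxyphenyl: an expected loss

The compounds below may be only part of what the source reports. "The series", "measured", "known", "first", "only" and "open" are said of these compounds alone.

Three measured compounds share one core and differ only in the aryl group on a carbon with a double bond to nitrogen. Compound 1 `COc1ccc(OC)c(/C=N/NC(=O)Nc2ccc(Oc3ccnc(-c4nncn4CCN(C)C)c3)c(F)c2)c1` carries a 2,5-dimethoxyphenyl there; in a functional assay on U-87MG ATCC cells (Homo sapiens) for cytotoxicity, read by MTT assay, with a stated time of 72 h (on this read-out lower numbers stand for stronger inhibition and higher numbers for weaker inhibition), compound 1 gives 6400 nM. Compound 2 `COc1ccc(/C=N/NC(=O)Nc2ccc(Oc3ccnc(-c4nncn4CCN(C)C)c3)c(F)c2)c(OC)c1` carries a 2,4-dimethoxyphenyl, and in this assay compound 2 gives 12600 nM, a change that is a 2.0-fold higher number from compound 1 to compound 2 (0.29 log units; within the scatter). Compound 3 `CN(C)CCn1cnnc1-c1cc(Oc2ccc(NC(=O)N/N=C/c3cc(Br)c(O)c(Br)c3)cc2F)ccn1` carries a 3,5-dibromo-4-hydroxyphenyl; in this assay compound 3 reaches only a limit, > 100000 nM. Of the two numbers given, compound 2 has the highest, with compound 1 as its nearest neighbour.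

The unmeasured compound 4 `CN(C)CCn1cnnc1-c1cc(Oc2ccc(NC(=O)N/N=C/c3ccc(O)cc3)cc2F)ccn1` arises from compound 2 by the change (4-hydroxyphenyl in place of 2,4-dimethoxyphenyl on a carbon with a double bond to nitrogen). Going by the values given here, two measured steps bear on it: an at least 15-fold higher number from compound 1 to compound 3 (1.19 log units; beyond the scatter) and an at least 7.9-fold higher number from compound 2 to compound 3 (0.89 log units; beyond the scatter). Both replace a dimethoxyphenyl with a hydroxy-bearing ring and both lose activity beyond the scatter, the second resting on (the limit of > 100000 nM in this assay, at which 1 of the 3 values shown sits). Compound 4 carries the hydroxy group but not the two bromo groups, so the step is expected to go the same way, possibly less far. In this assay compound 4 is therefore expected to give about 40000 nM, between 15000 nM and 110000 nM. The expected step is a 3.2-fold higher number from compound 2 to compound 4 (0.50 log units; beyond the scatter).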

Compound 4, half-maximal inhibitory concentration: 7750 nM
Compound 4: middle estimate off by 5.2-fold (0.71 log units), on the high side, outside the stated range (below it).
By their numbers in this assay, from the lowest: compounds 1, 4 and 2 (each within the scatter of the next). At a limit, above all of these: compound 3.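

In this assay, a 4-hydroxyphenyl on this carbon stands level with both dimethoxyphenyl groups: the exchange gives a 1.6-fold lower number from compound 2 to compound 4 (0.21 log units; within the scatter) and, against the other dimethoxyphenyl, a 1.2-fold higher number from compound 1 to compound 4 (0.08 log units; within the scatter). So the hydroxy group, with its hydrogen-bond donor, does not by itself go with the loss that compound 3 suggested, and neither of the two methoxy groups is needed to hold this level among the compounds shown. The one new step beyond the scatter is an at least 12-fold lower number from compound 3 to compound 4 (1.11 log units; beyond the scatter), where the two bromo groups are the only difference, and the value of compound 3 in that step is a limit and not a number: the limit of > 100000 nM in this assay, at which 1 of the 4 values shown sits.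

The compounds shown leave open whether a single bromo group, as in a 3-bromo-4-hydroxyphenyl, already goes with that step or whether it takes both. They also leave open how a plain phenyl, a 4-methoxyphenyl, a 4-aminophenyl or a 4-carboxyphenyl on this carbon would compare with compound 4 in this assay.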